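This account rests on a few compounds, and the source may have more. Where it says the series, first, only, none or still open, it means among the compounds named here.

Measured so far in a functional assay on MCF7 cells (Homo sapiens) for cytotoxicity, read by MTT assay, with a stated time of 48 h; on this read-out lower numbers stand for stronger inhibition and higher numbers for weaker inhibition:
Compound 1 `C/C(=N\NC(=S)Nc1ccccc1I)c1ccccn1`: 4.1 nM
Compound 2 `C/C(=N/NC(=S)Nc1ccccc1I)c1ccccn1`: 4.1 nM

Compound 1 has a single measured neighbour, and the two sit level: the step is no change at the digits printed from compound 1 to compound 2 (within the scatter). Compound 3 `C/C(=N\NC(=S)Nc1ccccc1)c1ccccn1` keeps the core of compound 1 and makes one change: hydrogen in place of iodo on an aromatic carbon, with hydrogen in place of iodo on an aromatic carbon of a six-membered aromatic ring of carbon only. Among the compounds with values here, the one measured step rests on (the fact that compounds 1 and 2 differ only in the configuration as drawn), so it gives no size for losing the iodo group. The starting point is therefore compound 1 at 4.1 nM, and only a modest move toward weaker inhibition is expected, with wide uncertainty in both directions. The expected change is a 2.0-fold higher number from compound 1 to compound 3 (0.29 log units; within the scatter). For compound 3 the estimated value is 8 nM, with a range of 1.5 nM to 50 nM.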

Compound 3, half-maximal inhibitory concentration: 0.18 nM
Compound 3: middle estimate off by 44-fold (1.65 log units), on the high side; the measured number lies below the stated range.
By their numbers in this assay, from the lowest: compound 3; then compounds 1 and 2 (each within the scatter of the next).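

In this assay, the iodo group is not needed for activity at this position: with hydrogen in its place the step is a 23-fold lower number from compound 1 to compound 3 (1.36 log units; beyond the scatter), a large move toward stronger inhibition. The earlier pair left this aromatic carbon unchanged, and this step shows that the read-out responds strongly to what sits there. Nothing given here explains the size of this step.

Only iodo and hydrogen are shown at this place, so it remains open whether any group there weakens inhibition or whether the effect is particular to iodo; a fluoro group, a methyl group or an amine could land anywhere relative to these two. From the compounds shown here alone, it also remains open whether the double-bond configuration, which changed nothing at the digits printed with iodo present, would matter with hydrogen there.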